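This account rests on a few compounds, and the source may have more. Where it says the series, first, only, none or still open, it means among the compounds named here.

Measured so far:
compound 1 `COc1cc2nnc(C(N)=O)c(Nc3ccc(C)cc3F)c2cc1N1C[C@@H](C)N[C@@H](C)C1` – 4.4 h
compound 2 `COc1cc2nnc(C(N)=O)c(Nc3ccc(C)cc3F)c2cc1N1CCC(N(C)C)CC1` – 0.9 h

In an ADME assay on the whole organism for metabolic stability, with Rattus norvegicus as the target (on this read-out higher numbers stand for a longer-lived compound and lower numbers for a shorter-lived compound), compound 2 gives 0.9 h, the lowest of the two numbers. For the measured compounds named here, the single measured step is a 4.9-fold lower number from compound 1 to compound 2 (0.69 log units; beyond the scatter). Compound 3 `COc1cc2nnc(C(N)=O)c(Nc3ccc(C)cc3F)c2cc1N1CCN(S(C)(=O)=O)CC1` differs from compound 2 by 4-(methylsulfonyl)piperazin-1-yl in place of 4-(dimethylamino)piperidin-1-yl on an aromatic carbon. That measured step concerns a different replacement at the same aromatic carbon and bears on this change only loosely, so no step beyond the scatter is firmly expected in this assay. Compound 3 is estimated at 1.5 h, within a range from 0.5 h to 4.5 h. This estimate corresponds to an expected 1.7-fold higher number from compound 2 to compound 3 (0.22 log units; within the scatter).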

Compound 3, half-life: 1.5 h
For compound 3 middle estimate and measured number coincide at the digits printed; the measured number falls inside the stated range.
By their numbers in this assay, from the lowest: compounds 2 and 3 (each within the scatter of the next); then compound 1.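

In this assay the aromatic carbon ortho to a methoxy group now carries three groups, and 4-(methylsulfonyl)piperazin-1-yl in place of 4-(dimethylamino)piperidin-1-yl gives a 1.7-fold higher number from compound 2 to compound 3 (0.22 log units; within the scatter) and so does not separate these two groups. In place of 3,5-dimethylpiperazin-1-yl the same group gives a 2.9-fold lower number from compound 1 to compound 3 (0.47 log units; beyond the scatter) and thus leaves compound 1 apart from both others. No measurement at hand accounts for this.

Open, on these data alone, is how a plain piperazin-1-yl or a morpholin-4-yl at this carbon would compare with compound 1, and so whether the two methyl groups of 3,5-dimethylpiperazin-1-yl set it apart.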